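Swapping Dichlorophenyl for Methylphenyl on the Shared Core

This account rests on a few compounds, and the source may have more. Where it says the series, first, only, none or still open, it means among the compounds named here.

Compound 1 `COc1cccc(/C=C/C(=O)c2sc(Nc3cccc(C)c3)nc2C)c1`: in a functional assay on PC-3 cells (Homo sapiens) for cytotoxicity, read by MTT assay (on this read-out lower numbers stand for stronger inhibition and higher numbers for weaker inhibition), compound 1 reaches only the assay limit > 25000 nM.
Compound 2 `Cc1nc(Nc2cccc(Cl)c2)sc1C(=O)/C=C/c1ccccc1`: in this assay compound 2 likewise reaches only the limit > 25000 nM.
Compound 3 `Cc1nc(Nc2ccc(Cl)c(Cl)c2)sc1C(=O)/C=C/c1ccccc1`: in this assay compound 3 gives 7990 nM.

Going by the values given here, compound 3 holds the only real number; the other two values are limits (the limit of > 25000 nM in this assay, at which 2 of the 3 values shown sit). Among the compounds with values here, the sole measured step, an at least 3.1-fold lower number from compound 2 to compound 3 (0.49 log units; beyond the scatter), shows that adding a chloro moved the number off the limit. Compound 4 `Cc1cccc(Nc2nc(C)c(C(=O)/C=C/c3ccccc3)s2)c1` reverses that direction: 3-methylphenyl in place of 3,4-dichlorophenyl on a nitrogen on an aromatic ring. The chlorines leave, and compound 1, which also carries 3-methylphenyl, sits at the limit. The expected outcome is therefore a return toward the limit, a rise of a 3.1-fold higher number from compound 3 to compound 4 (0.50 log units; beyond the scatter) in this assay. Compound 4 is estimated at 25000 nM, within 9000 nM to 70000 nM, and most likely reported only as a limit.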

Compound 4, half-maximal inhibitory concentration: 11700 nM
Estimate against measurement, compound 4: 2.1-fold (0.33 log units) above, and the stated range covers the measured number.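

In this assay, 3-methylphenyl and 3,4-dichlorophenyl on this nitrogen give values within the usual scatter of each other, with a 1.5-fold higher number from compound 3 to compound 4 (0.17 log units; within the scatter). Chlorines are therefore not required to bring this series off the limit, since compound 4 carries none and still gives a real number. The other two steps, an at least 2.1-fold lower number from compound 2 to compound 4 (0.32 log units; beyond the scatter) with methyl in place of chloro and an at least 2.1-fold lower number from compound 1 to compound 4 (0.32 log units; beyond the scatter) with hydrogen in place of methoxy, start from a limit rather than a number: the limit of > 25000 nM in this assay, at which 2 of the 4 values shown sit.

From the compounds shown here alone, what an amine or a carboxylic acid in place of the methyl on this aromatic ring would do remains open.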